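Compound 2 and the step to a pyrrole

The compounds below may be only part of what the source reports. "The series", "measured", "known", "first", "only" and "open" are said of these compounds alone.

compound 1 `O=C(Nc1ccc(-c2cscn2)cc1)[C@@H]1CCCN(Cc2ccc(F)c(F)c2)C1`: 6000 nM
compound 2 `O=C(Nc1ccc(-c2cscn2)cc1)[C@H]1CCCN(Cc2ccc(F)c(F)c2)C1`: 190 nM

In a functional assay on A-375 cells (Homo sapiens) for antiproliferative activity (a lower number here means a stronger inhibitor, a higher number a weaker inhibitor), compound 2 has the lower number of the two at 190 nM, so it is the stronger inhibitor. Going by the values given here, the only measured step, a 32-fold lower number from compound 1 to compound 2 (1.50 log units; beyond the scatter), is large, and it traces to the fact that compounds 1 and 2 differ only in the configuration as drawn. Compound 3 `O=C(Nc1ccc(-c2ccc[nH]2)cc1)[C@H]1CCCN(Cc2ccc(F)c(F)c2)C1` keeps the drawn configuration of compound 2 and changes another place: 1H-pyrrol-2-yl in place of 1,3-thiazol-4-yl on an aromatic carbon. Among the compounds with values here, no measured step touches this group, so that large step says nothing about its size, and no step beyond the scatter is expected in this assay. For compound 3 the estimated value is 250 nM, with an expected range of 70 nM to 900 nM. The expected change is a 1.3-fold higher number from compound 2 to compound 3 (0.12 log units; within the scatter).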

Compound 3, half-maximal inhibitory concentration: 190 nM
Compound 3: the middle estimate sits 1.3-fold (0.12 log units) above what was measured; low and high end bracket the measured number.
By their numbers in this assay, from the lowest: compounds 2 and 3 (each within the scatter of the next); then compound 1.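

In this assay, replacing 1,3-thiazol-4-yl with 1H-pyrrol-2-yl gives no change at the digits printed from compound 2 to compound 3 (within the scatter), so this aromatic carbon carries either ring with the same result. The entering ring has a hydrogen-bond donor and no acceptors, the leaving ring has acceptors and no donor, and the two numbers still match. Nothing available explains this match.

Still open, from the compounds shown here alone, is whether a pyridine ring, or a smaller group such as an amine or a carboxylic acid, would hold the number here. Also open, going by these compounds, is whether the pyrrole behaves alike in the configuration of compound 1.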